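Trimethoxyphenyl chalcone-pyrazole series: cytotoxicity notes

The source may report more compounds than this note shows. Statements on the series, on what has been measured and on what is new or still open speak of the compounds shown alone.

Measured so far in a functional assay on MDA-MB-468 cells (Homo sapiens) for cytotoxicity, read by sulforhodamine B assay, with a stated time of 48 h, tested at 10 uM; a lower number here means a stronger effect, a higher number a weaker effect of the compound at the concentration tested:
compound 1 `COc1cc(-c2cc(/C=C/C(=O)c3ccc(N)cc3)[nH]n2)cc(OC)c1OC` gives -58%;
compound 2 `COc1ccc(-c2cc(/C=C/C(=O)c3ccc(N)cc3)[nH]n2)cc1OC` gives -65%;
compound 3 `COc1cc(C(=O)/C=C/c2cc(-c3cc(OC)c(OC)c(OC)c3)n[nH]2)cc(OC)c1OC` gives -90%.

Compound 3 has the lowest number of the three, and its gap to each of the others is beyond the scatter, so within this set it shows the strongest effect. How the core of compound 3 differs from the core of compound 1 is not broken down here.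

Compounds 1 and 2 differ by one change, (hydrogen in place of methoxy on an aromatic carbon). The step is a number 7 percentage points lower from compound 1 to compound 2 (within the scatter), which is within the scatter.

Compound 4 `COc1ccc(-c2cc(/C=C/C(=O)c3cc(OC)c(OC)c(OC)c3)[nH]n2)cc1OC` is not yet measured. It differs from compound 3 by hydrogen in place of methoxy on an aromatic carbon. The place described around this change reads the same as for the change from compound 1 to compound 2, so it is the same change, seen a second time in the series.

Since the earlier step of a number 7 percentage points lower from compound 1 to compound 2 (within the scatter) stayed within the scatter, a step of similar size is expected here, a number 1 percentage points lower from compound 3 to compound 4 (within the scatter). Compound 4 is therefore estimated at -91% in this assay, between -100% and -78%.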

Compound 4, a percentage reported as activity, at one concentration (the size of the read-out at that concentration, not a potency): -62%
Compound 4: middle estimate off by 29 percentage points, on the low side, outside the stated range (above it).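

In this assay, hydrogen in place of methoxy gives a number 28 percentage points higher from compound 3 to compound 4 (beyond the scatter), so the change did not carry over with the same result from one core to the other: the same change on two cores in this assay, a number 7 percentage points lower (within the scatter) from compound 1 to compound 2 and a number 28 percentage points higher (beyond the scatter) from compound 3 to compound 4, 35 percentage points apart, beyond the scatter of two such steps

Going by these compounds alone, in these two pairs, then, the outcome of the same change depends on the core it sits on, and the step within the scatter on the core of compound 1 was no guide to the step on the core of compound 3. The two pairs do not show which feature of the cores accounts for the difference, nor how the change would read on a third core.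

Open, going by these compounds, is whether another group at the same place, such as hydroxy, fluorine or the longer ethoxy chain, would read like methoxy or like hydrogen on either core. Also open, on these data alone, is how the pair would read on a core carrying a carboxylic acid where compound 1 and compound 2 carry their amine.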